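This account rests on a few compounds, and the source may have more. Where it says the series, first, only, none or still open, it means among the compounds named here.

Compound 1, `CC[C@H]1CC[C@H](c2ccc(NC(=S)Nc3cccc(C(F)(F)F)c3)cc2)CC1`: 10000 nM
Compound 2, `Fc1ccc(NC(=S)Nc2cccc(C(F)(F)F)c2)cc1Cl`: 20000 nM
Compound 3, `CC(=O)NC(=S)Nc1cccc(C(F)(F)F)c1`: > 100000 nM

In an ADME assay on Vero 76 cells (Chlorocebus sabaeus) for cytotoxicity, read by crystal violet staining, with a stated time of 96 h (on this read-out lower numbers stand for higher toxicity in this test and higher numbers for lower toxicity in this test), compound 1 gives 10000 nM, the lower of the two numbers recorded. Compound 2 gives 20000 nM in this assay, a gap that lies within the scatter of this measurement, so the two cannot be ordered. For compound 3 only a limit is reported, > 100000 nM, which is the limit of > 100000 nM in this assay, at which 1 of the 3 values shown sits. Compound 4, `N#Cc1ccc(NC(=S)Nc2cccc(C(F)(F)F)c2)cc1`, has not yet been measured in this assay; it differs from compound 1 by cyano in place of 4-ethylcyclohexyl on an aromatic carbon. Within the data shown here, no measured step between two compounds covers this change, so the size of the step is unknown. Compound 4 is expected to give about 40000 nM in this assay, within 15000 nM to 100000 nM. The expected step, a 4.0-fold higher number from compound 1 to compound 4 (0.60 log units; beyond the scatter), would be toward a higher number, and only its upper part would lie beyond the scatter.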

Compound 4, half-maximal cytotoxic concentration: 10000 nM
Estimate against measurement, compound 4: 4.0-fold (0.60 log units) above; the measured number lies below the stated range.
By their numbers in this assay, from the lowest: compounds 1, 4 and 2 (each within the scatter of the next). At a limit, above all of these: compound 3.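

In this assay, putting cyano in place of 4-ethylcyclohexyl on the aromatic carbon gives no change at the digits printed from compound 1 to compound 4 (within the scatter). At this position, the large carbon-only ring and its defined stereocentres can therefore give way to a much smaller group carrying a hydrogen-bond acceptor without a measurable shift in this test. Nothing measured here bears on why the two numbers agree. Going by these compounds, whether this tolerance extends to other groups at this position remains open, for example an amine, a carboxylic acid or a straight alkyl chain.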